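Methyl on the linker carbon of compound 1

The source may report more compounds than this note shows. Statements on the series, on what has been measured and on what is new or still open speak of the compounds shown alone.

Measured compounds:
compound 1 `O=C(O)Cc1nn(Cc2nc3cc(Cl)ccc3s2)c(=O)c2ccccc12` — 73%
compound 2 `O=C(O)Cc1nn(Cc2nc3cc(Cl)cc(Cl)c3s2)c(=O)c2ccccc12` — 73%

In an in vivo functional assay on the whole organism for inhibition of sorbitol dehydrogenase (Rattus norvegicus), at a dose of 10 mg/kg by the oral route (on this read-out lower numbers stand for less inhibition and higher numbers for more inhibition at the one dose given (going by the name of the read-out)), compound 1 gives 73% and compound 2 gives 73%. Among the compounds with values here, the only measured step, no change at the digits printed from compound 1 to compound 2 (within the scatter), is a chloro in place of hydrogen on an aromatic carbon; compound 1 stands level with compound 2, and nothing in the pair separates them.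

Compound 3 `CC(c1nc2cc(Cl)ccc2s1)n1nc(CC(=O)O)c2ccccc2c1=O` differs from compound 1 by methyl in place of hydrogen on a saturated chain carbon bound to an aromatic carbon and an aromatic nitrogen. Within the data shown here, no measured step touches this place in the core of compound 1: the single known step concerns an aromatic carbon, not the saturated chain carbon bound to an aromatic carbon and an aromatic nitrogen. The step from compound 1 to compound 3 in this assay is therefore expected to be small, a number 5 percentage points lower from compound 1 to compound 3 (within the scatter), with no direction supported by the data. Compound 3 is estimated at 68%, in the range 45% to 85%, the width reflecting the absence of a comparable measured step.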

Compound 3, a percentage reported as inhibition, in the whole organism at one dose (the size of the read-out at that dose, not a potency): 53%
Beside the measured number, compound 3's estimate is 15 percentage points above it; the measured number falls inside the stated range.
By their numbers in this assay, from the lowest: compound 3; then compounds 1 and 2 (each within the scatter of the next).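

In this assay, within the data shown here, the saturated chain carbon bound to an aromatic carbon and an aromatic nitrogen proves sensitive to substitution: methyl in place of hydrogen there gives a number 20 percentage points lower from compound 1 to compound 3 (beyond the scatter) and is the first change to exceed the scatter. The chloro in place of hydrogen on an aromatic carbon, by contrast, gives no change at the digits printed from compound 1 to compound 2 (within the scatter) and so leaves the read-out unmoved. No available measurement accounts for the lower number with the methyl.

As far as these compounds go, whether an ethyl group or a longer chain on this same carbon would lower the read-out further, or a fluoro group there would match hydrogen or methyl, remains open. Also open, from the compounds shown here alone, is whether the methyl step would carry over to compound 2, with its second chloro.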